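The source may hold more compounds than are shown below. What is called first, only, known or untested is meant among the compounds shown, and "the series" means these compounds.

In a functional assay on PC-9 cells (Homo sapiens) for inhibition, read by MTT assay, with a stated time of 72 h (on this read-out higher numbers stand for weaker inhibition and lower numbers for stronger inhibition), three compounds built on the same core have been measured so far. Compound 1 `Cc1cc(Nc2cc(-c3ccccc3)[nH]n2)n2nc(SCC3CCCCC3)nc2n1`, with cyclohexyl on a saturated chain carbon bound to a sulfur, gives > 50000 nM, which is a limit of the assay and not a number. Compound 2 `Cc1cc(Nc2cc(-c3ccccc3)[nH]n2)n2nc(SCc3ccccc3Br)nc2n1`, with 2-bromophenyl at that place, gives 5630 nM. Compound 3 `Cc1cc(Nc2cc(-c3ccccc3)[nH]n2)n2nc(SCCCc3ccccc3)nc2n1`, with phenethyl there, gives 5030 nM. For the measured compounds named here, the comparison shows a 1.1-fold lower number from compound 2 to compound 3 (0.05 log units; within the scatter), so these two stand level and hold the only true numbers so far.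

Compound 4 `Cc1cc(Nc2cc(-c3ccccc3)[nH]n2)n2nc(SCc3csc4ccccc34)nc2n1` brings one further change: 1-benzothiophen-3-yl in place of phenethyl on a saturated chain carbon bound to a sulfur. In other words, 3-phenylpropyl gives way to (1-benzothiophen-3-yl)methyl.

Two measured steps show what an aromatic group brought in place of cyclohexyl: an at least 8.8-fold lower number from compound 1 to compound 2 (0.94 log units; beyond the scatter) and an at least 9.9-fold lower number from compound 1 to compound 3 (0.99 log units; beyond the scatter). Compound 4 keeps an aromatic group at this place, so the closer guide is the exchange of one aromatic group for another, which gave a 1.1-fold lower number from compound 2 to compound 3 (0.05 log units; within the scatter). On that basis, no change beyond the scatter is expected here, in either direction, and the estimated step is a 1.0-fold lower number from compound 3 to compound 4 (0.00 log units; within the scatter). For compound 4 the expected value is 5000 nM, with an estimated range from 1800 nM to 15000 nM.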

Compound 4, half-maximal inhibitory concentration: 4420 nM
Compound 4: middle estimate off by 1.1-fold (0.05 log units), on the high side, within the range that was stated.
By their numbers in this assay, from the lowest: compounds 4, 3 and 2 (each within the scatter of the next). At a limit, above all of these: compound 1.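

Compound 4 adds a third aromatic group at this place on a saturated chain carbon bound to a sulfur, and it stands level with the other two, with a 1.1-fold lower number from compound 3 to compound 4 (0.06 log units; within the scatter) and a 1.3-fold lower number from compound 2 to compound 4 (0.11 log units; within the scatter) in this assay. So a second ring fused to the first, a ring sulfur and a shorter link, with (1-benzothiophen-3-yl)methyl in place of 3-phenylpropyl, together leave the number within the scatter, while an at least 11-fold lower number from compound 1 to compound 4 (1.05 log units; beyond the scatter) makes compound 4 the third compound with an aromatic group to stand clear of cyclohexyl-bearing compound 1. The value of compound 1 is a limit and not a number, so the true size of this last step stays unknown because the comparison rests on that limit: the limit of > 50000 nM in this assay, at which 1 of the 4 values shown sits.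

The compounds shown leave open whether any group at this place can bring the number clearly below the level shared by compounds 2, 3 and 4, and whether a pyridine ring, an amine or a carboxylic acid would hold that level. Also open, on these data alone, is whether a plain butyl chain with no ring would behave like the cyclohexyl of compound 1 or like the aromatic groups.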